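The source may report more compounds than this note shows. Statements on the series, on what has been measured and on what is new or still open speak of the compounds shown alone.

Working notes on the series. Compound 1 `COc1ccc(/C=C/C[C@H]2C[C@@H]([C@@H](O)c3ccccc3)CO[C@@H]2c2ccccc2)cc1` in a functional assay on HL-60 cells (Homo sapiens) for cytotoxicity, read by WST assay, with a stated time of 48 h (on this read-out higher numbers stand for weaker inhibition and lower numbers for stronger inhibition), gives 9010 nM. Compound 2 `Oc1cccc(/C=C/C[C@H]2C[C@@H]([C@@H](O)c3ccccc3)CO[C@@H]2c2ccccc2)c1` gives 12800 nM, and compound 3 `O=[N+]([O-])c1ccccc1/C=C/C[C@H]1C[C@@H]([C@@H](O)c2ccccc2)CO[C@@H]1c1ccccc1` gives 7250 nM. Compound 1 stands second highest of the three numbers; its nearest neighbour is compound 3 and its furthest is compound 2, and both gaps lie within the scatter. The step of a 1.4-fold higher number from compound 1 to compound 2 (0.15 log units; within the scatter) and the step of a 1.2-fold lower number from compound 1 to compound 3 (0.09 log units; within the scatter) are both within the scatter, as is a 1.8-fold lower number from compound 2 to compound 3 (0.25 log units; within the scatter), so the three aryl groups on the double-bonded chain carbon are not separated by these numbers.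

Compound 4 `O[C@@H](c1ccccc1)[C@H]1CO[C@H](c2ccccc2)[C@@H](C/C=C/c2cccnc2)C1` differs from compound 1 as follows: pyridin-3-yl in place of 4-methoxyphenyl on a double-bonded chain carbon bound to a double-bonded chain carbon. For the measured compounds named here, the change sits at the same place that is varied across compounds 1, 2 and 3, where no step exceeded the scatter. No step beyond the scatter is therefore expected for compound 4 in this assay. The expected step is a 1.0-fold lower number from compound 1 to compound 4 (0.00 log units; within the scatter). Compound 4 is estimated to give 9000 nM, with a range from 4000 nM to 20000 nM.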

Compound 4, half-maximal inhibitory concentration: > 100000 nM
Compound 4 ended at the assay's limit; the forecaster's own chance of this, stated with the estimate: 5%; at least 11-fold (1.04 log units) between middle value and limit.
By their numbers in this assay, from the lowest: compounds 3, 1 and 2 (each within the scatter of the next). At a limit, above all of these: compound 4.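

In this assay compound 4 returns a limit and not a number: the limit of > 100000 nM in this assay, at which 1 of the 4 values shown sits.

The place on a double-bonded chain carbon bound to a double-bonded chain carbon therefore does respond to the group it carries, which compounds 1, 2 and 3 could not show: pyridin-3-yl gives an at least 11-fold higher number from compound 1 to compound 4 (1.04 log units; beyond the scatter), an at least 13-fold higher number from compound 3 to compound 4 (1.13 log units; beyond the scatter) and an at least 7.8-fold higher number from compound 2 to compound 4 (0.89 log units; beyond the scatter). Among the compounds shown, the three with a carbon-only aromatic ring here stay within the scatter of one another, and the single ring with a hetero atom stands apart, so this contrast rests on compound 4 alone.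

From the compounds shown here alone, how far compound 4 lies past the limit remains unknown. Also open, going by these compounds, is whether the limit goes with the ring nitrogen or with the lack of a ring substituent, a question that an unsubstituted phenyl and a methoxy-bearing pyridin-3-yl at this place would address.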